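Amide Replaces Formamidine on a Cyanopyridone Anti-Edema Core

The source may hold more compounds than are shown below. What is called first, only, known or untested is meant among the compounds shown, and "the series" means these compounds.

Measured in a functional assay on the whole organism (strain albino) for inhibition, with Rattus norvegicus as the target, read by paw edema, with stated times of 1 h and 3 h, at a dose of 20 mmol/kg by the intraperitoneal route (on this read-out lower numbers stand for a weaker effect and higher numbers for a stronger effect at the one dose given), so far:
- compound 1, `N#CC1=C(NCC(=O)N2CCOCC2)N(c2ccccc2)C(=O)N2CCCCC(N3CCCC3)C12`: 73.5%
- compound 2, `N#CC1=C(NCN2CCCC2)N(c2ccccc2)C(=O)N2CCCCC(N3CCCC3)C12`: 35.3%
- compound 3, `N#CC1=C(/N=C/Nc2ccccc2)N(c2ccccc2)C(=O)N2CCCCC(N3CCCC3)C12`: 79.3%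

Compound 3 holds the highest number of the three. Against compound 1 the step of a number 5.8 percentage points higher from compound 1 to compound 3 (within the scatter) is small, so the two cannot be ranked; against compound 2 the step of a number 44 percentage points higher from compound 2 to compound 3 (beyond the scatter) is large and clear, as is a number 38.2 percentage points lower from compound 1 to compound 2 (beyond the scatter), where the carbonyl-bearing chain gave way to a pyrrolidinyl group.

Compound 4, `N#CC1=C(NC(=O)c2ccccc2O)N(c2ccccc2)C(=O)N2CCCCC(N3CCCC3)C12`, differs from compound 3 in one place: a group of 10 heavy atoms (7 carbon, 1 nitrogen, 2 oxygen; one six-membered aromatic ring of carbon only) in place of a group of 9 heavy atoms (7 carbon, 2 nitrogen; one six-membered aromatic ring of carbon only), on a double-bonded ring carbon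

Among the compounds with values here, no measured step removes a carbon-nitrogen double bond or adds an amide, so none bears on this change directly. The two compounds that carry a carbonyl or an aromatic ring on this carbon, compound 1 and compound 3, sit close together, and compound 4 keeps both features, so little movement is expected in this assay. The estimate for compound 4 is 70%, within 50% to 88%, which means an expected step of a number 9.3 percentage points lower from compound 3 to compound 4 (within the scatter), not beyond the scatter.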

Compound 4, a percentage reported as inhibition, in the whole organism at one dose (the size of the read-out at that dose, not a potency): 65.4%
Estimate against measurement, compound 4: 4.6 percentage points above, within the range that was stated.
By their numbers in this assay, from the lowest: compound 2; then compounds 4, 1 and 3 (each within the scatter of the next, the first and the last beyond it).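

In this assay, putting ((2-hydroxyphenyl)carbonyl)amino on the double-bonded ring carbon in place of the formamidine-type group gives a number 13.9 percentage points lower from compound 3 to compound 4 (beyond the scatter), so this position responds to the exchange, though only modestly. The amide holds up against the earlier chains on the amine nitrogen: a number 30.1 percentage points higher from compound 2 to compound 4 (beyond the scatter) is a large step, while a number 8.1 percentage points lower from compound 1 to compound 4 (within the scatter) cannot be read as a real difference, which places an aromatic amide on a par with the morpholine-bearing amide chain. Nothing in the data explains why these steps take the sizes they do.

Still open, on these data alone, is what the hydroxyl on the aromatic ring contributes, a question that a plain phenylcarbonyl or a (2-methoxyphenyl)carbonyl group on the same nitrogen would address. Also open, as far as these compounds go, is how an amide without an aromatic ring, such as acetyl, would compare.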